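This account rests on a few compounds, and the source may have more. Where it says the series, first, only, none or still open, it means among the compounds named here.

Measured so far in a functional assay on A549 cells (Homo sapiens) for cytotoxicity, read by MTT assay, with a stated time of 72 h; a higher number here means a weaker inhibitor, a lower number a stronger inhibitor:
compound 1 `O=C(Nc1nc2ccc(Cl)cc2s1)c1cn(-c2ccccc2)nc1-c1ccccc1` gives 7670 nM
compound 2 `COc1ccc2nc(NC(=O)c3cn(-c4ccccc4)nc3-c3ccccc3)sc2c1` gives > 50000 nM, which is a limit of the assay
compound 3 `O=C(Nc1nc2ccccc2s1)c1cn(-c2ccccc2)nc1-c1ccc(Cl)cc1` gives 10300 nM

Compound 1 and compound 3 share the same atoms joined differently; the difference between the two cores is not broken down here, and their two numbers lie within the scatter of each other. Going by the values given here, from compound 1 to compound 2 the change is methoxy in place of chloro on an aromatic carbon and the step is an at least 6.5-fold higher number from compound 1 to compound 2 (0.81 log units; beyond the scatter), the one value being only a limit (the limit of > 50000 nM in this assay, at which 1 of the 3 values shown sits).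

Compound 4 `COc1ccc(-c2nn(-c3ccccc3)cc2C(=O)Nc2nc3ccccc3s2)cc1` carries the same kind of change against compound 3, (methoxy in place of chloro on an aromatic carbon). The surroundings differ: in compound 2 the methoxy sits on a ring that is part of a fused or bridged system of two rings, meta to a fused ring and para to a fused ring, whereas in compound 4 it sits on a six-membered aromatic ring of carbon only, para to a large group. Compound 4 is expected to show a 3.4-fold higher number from compound 3 to compound 4 (0.53 log units; beyond the scatter), because an at least 6.5-fold higher number from compound 1 to compound 2 (0.81 log units; beyond the scatter) went that way. The estimate for compound 4 is 35000 nM, with a fair chance that only a limit is returned.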

Compound 4, half-maximal inhibitory concentration: 13700 nM
Compound 4: the middle estimate sits 2.6-fold (0.41 log units) above what was measured, and the stated range covers the measured number.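

In this assay, methoxy in place of chloro on the six-membered aromatic ring of carbon only gives a 1.3-fold higher number from compound 3 to compound 4 (0.12 log units; within the scatter), so the 4-chlorophenyl to 4-methoxyphenyl change leaves no step beyond the scatter on this core. The size of the change did not carry from one core to the other: the same change on two cores in this assay, an at least 6.5-fold higher number (0.81 log units; beyond the scatter) from compound 1 to compound 2 and a 1.3-fold higher number (0.12 log units; within the scatter) from compound 3 to compound 4, at least 4.9-fold (0.69 log units) apart, beyond the scatter of two such steps. Compound 2 stands only at a limit, so the full size of its step stays unknown, and with two pairs that differ in where the change sits, the role of that place cannot be separated from the role of the rest of the core: the limit of > 50000 nM in this assay, at which 1 of the 4 values shown sits.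

As far as these compounds go, whether an amine or a carboxylic acid in place of chloro would give a step beyond the scatter on either core stays open. So does whether a third pair would follow compound 3 to compound 4 or compound 1 to compound 2.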